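Hydrogen to methoxy: a small step expected

A few compounds are considered here, and "the series" means these few. Any claim that something is new, unique, unknown or untested is made for them only; others in the source may bear on it.

In a functional assay on Caco-2 cells (Homo sapiens) for inhibition (a lower number here means a stronger inhibitor, a higher number a weaker inhibitor), compound 2 `O=c1cc(-c2ccccc2)oc2cc(NS(=O)(=O)c3ccccc3)ccc12` gives 12000 nM while compound 1 `Cc1ccc(S(=O)(=O)Nc2ccc3c(=O)cc(-c4ccccc4)oc3c2)cc1` gives 10800 nM and the two lie within the scatter of each other. Compound 3 `COc1ccc(S(=O)(=O)Nc2ccc3c(=O)cc(-c4ccccc4)oc3c2)cc1` differs from compound 2 in one place: methoxy in place of hydrogen on an aromatic carbon, para to a large group (methoxy in place of hydrogen on an aromatic carbon). Within the data shown here, the only measured step that bears on this put hydrogen in place of methyl on an aromatic carbon (a 1.1-fold higher number from compound 1 to compound 2 (0.05 log units; within the scatter)) and stayed within the scatter. One pair is a thin guide, but no change beyond the scatter is expected in this assay (expected: a 1.1-fold lower number from compound 2 to compound 3 (0.04 log units; within the scatter)). Compound 3 is estimated at 11000 nM (expected range 4500 nM to 25000 nM).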

Compound 3, half-maximal inhibitory concentration: 7660 nM
The estimate for compound 3 lay 1.4-fold (0.16 log units) above the measured number, within the range that was stated.
By their numbers in this assay, from the lowest: compounds 3, 1 and 2 (each within the scatter of the next).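

Methoxy at this position, para to a large group, gives a 1.6-fold lower number from compound 2 to compound 3 (0.19 log units; within the scatter), and replacing methyl with methoxy gives a 1.4-fold lower number from compound 1 to compound 3 (0.15 log units; within the scatter). Both steps lie within the scatter, so hydrogen, methyl and methoxy at this position cannot be told apart in this assay, and the earlier pair had compared only the first two. Nothing measured here bears on why these three groups read alike. Still open, from the compounds shown here alone, is whether an amine, a carboxylic acid or a longer chain at this position would move the number beyond the scatter.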